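This account rests on a few compounds, and the source may have more. Where it says the series, first, only, none or still open, it means among the compounds named here.

Measured in a physicochemical assay for solubility, read by LC-MS, in phosphate buffer, with a stated time of 24 h, at pH 7.4; on this read-out lower numbers stand for lower solubility and higher numbers for higher solubility:
- compound 1 `Cc1nccn1-c1cnc(NCc2c(F)ccc3c2CCO3)c2cn[nH]c(=O)c12` gives 7000 nM
- compound 2 `CN(C)C(=O)c1cc(-c2cnc(NCc3c(F)ccc4c3CCO4)c3cn[nH]c(=O)c23)n(C)n1` gives 3000 nM
- compound 3 `Cc1nc(CN(C)C)ccc1-c1cnc(NCc2c(F)ccc3c2CCO3)c2cn[nH]c(=O)c12` gives > 1000000 nM (a limit, not a number)

Compound 3 has no exact value, only the limit > 1000000 nM of the assay. It stands well apart from the other two, so every step to it is a bound.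

Compound 4 `CNC(=O)c1ccc(-c2cnc(NCc3c(F)ccc4c3CCO4)c3cn[nH]c(=O)c23)c(C)n1` differs from compound 3 at one place, (methylcarbamoyl in place of (dimethylamino)methyl on an aromatic carbon), with methylcarbamoyl in place of (dimethylamino)methyl on an aromatic carbon, next to the ring nitrogen.

Going by the values given here, no measured step makes this exact swap. The nearest are an at least 140-fold higher number from compound 1 to compound 3 (2.15 log units; beyond the scatter) and an at least 330-fold higher number from compound 2 to compound 3 (2.52 log units; beyond the scatter), both large and both bounded by the limit. Each brings in the 6-((dimethylamino)methyl)-2-methylpyridin-3-yl group, which compound 4 no longer carries in full. Between the two compounds without that group, a 2.3-fold lower number from compound 1 to compound 2 (0.37 log units; beyond the scatter) is only modest. Among the compounds with values here, compound 2, at 3000 nM, is the one measured compound with a carbamoyl group, though three compounds are too few for a rule.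

A large step down in this assay is therefore expected, estimated as an at least 200-fold lower number from compound 3 to compound 4 (2.30 log units; beyond the scatter). For compound 4 the estimated value is 5000 nM, with an expected range of 1000 nM to 30000 nM.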

Compound 4, solubility: 19000 nM
Compound 4: middle estimate off by 3.8-fold (0.58 log units), on the low side; measured number inside the range.
By their numbers in this assay, from the lowest: compound 2; then compound 1; then compound 4. At a limit, above all of these: compound 3.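

In this assay, going by these compounds alone, the earlier steps replaced the whole substituent on the core, whereas this one keeps the six-membered aromatic ring and its methyl group and changes only the group next to the ring nitrogen, from (dimethylamino)methyl to methylcarbamoyl, giving an at least 52-fold lower number from compound 3 to compound 4 (1.72 log units; beyond the scatter). Within the data shown here, the size of this step is only a bound, as compound 3 stands at a limit and has no exact number: the limit of > 1000000 nM in this assay, at which 1 of the 4 values shown sits. Against the two other substituents, the 2-methyl-6-(methylcarbamoyl)pyridin-3-yl group gives only modest steps, a 6.3-fold higher number from compound 2 to compound 4 (0.80 log units; beyond the scatter) and a 2.7-fold higher number from compound 1 to compound 4 (0.43 log units; beyond the scatter), so in this set the single change at this position separates a reading at the limit from readings within a modest span of one another.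

The compounds shown leave open whether the large step is specific to (dimethylamino)methyl or would also appear with another amine at this position, such as a morpholinomethyl or a primary aminomethyl group. They also leave open whether a carboxylic acid or a longer chain on the same carbon would read like compound 4 or like compound 3.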